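Swapping the trimethoxyphenyl for a vanillyl-type ring

The source may hold more compounds than are shown below. What is called first, only, known or untested is meant among the compounds shown, and "the series" means these compounds.

Measured compounds:
compound 1 `COc1cc(/C=C/C(=O)c2cccc(-n3cc(-c4ccc(Cl)cc4)[nH]c3=O)c2)ccc1O` — 2750 nM
compound 2 `COc1cc(/C=C/C(=O)c2cccc(-n3cc(-c4ccccc4)[nH]c3=O)c2)ccc1O` — 3900 nM
compound 3 `COc1ccc(-c2cn(-c3cccc(C(=O)/C=C/c4cc(OC)c(OC)c(OC)c4)c3)c(=O)[nH]2)cc1` — 4590 nM

In a functional assay on SNB-75 cells (Homo sapiens) for inhibition (a higher number here means a weaker inhibitor of growth, a lower number a stronger inhibitor of growth), compound 3 gives 4590 nM, the highest of the three numbers, though its distance to compound 2 and to compound 1 lies within the scatter, so no order among the three can be claimed. Compound 4 `COc1ccc(-c2cn(-c3cccc(C(=O)/C=C/c4ccc(O)c(OC)c4)c3)c(=O)[nH]2)cc1` differs from compound 3 in one place: 4-hydroxy-3-methoxyphenyl in place of 3,4,5-trimethoxyphenyl on a double-bonded chain carbon bound to a double-bonded chain carbon. Going by the values given here, no measured pair changes this part of the molecule; the only measured step, a 1.4-fold higher number from compound 1 to compound 2 (0.15 log units; within the scatter), concerns the other aromatic ring and is itself within the scatter. Compounds 1 and 2 carry the entering 4-hydroxy-3-methoxyphenyl and give numbers close to compound 3, so nothing here points to a shift beyond the scatter. The step from compound 3 to compound 4 is therefore expected to be small, a 1.3-fold lower number from compound 3 to compound 4 (0.12 log units; within the scatter). Compound 4 is estimated at 3500 nM, with a range from 1500 nM to 8000 nM.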

Compound 4, concentration for 50% growth inhibition: 4730 nM
Compound 4: middle estimate off by 1.4-fold (0.13 log units), on the low side, and the stated range covers the measured number.
By their numbers in this assay, from the lowest: compounds 1, 2, 3 and 4 (each within the scatter of the next).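

In this assay, going by these compounds alone, the exchange of 3,4,5-trimethoxyphenyl for 4-hydroxy-3-methoxyphenyl gives a 1.0-fold higher number from compound 3 to compound 4 (0.01 log units; within the scatter) and is the first direct reading of this position, where the smaller group with its hydrogen-bond donor leaves the number within the scatter. With 4-hydroxy-3-methoxyphenyl held in place, the aromatic carbon of the other ring also stays within the scatter across three groups: methoxy in place of hydrogen gives a 1.2-fold higher number from compound 2 to compound 4 (0.08 log units; within the scatter) and methoxy in place of chloro gives a 1.7-fold higher number from compound 1 to compound 4 (0.24 log units; within the scatter) on that ring. No evidence at hand explains why these numbers stay so close.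

As far as these compounds go, both aryl groups tried at this position carry oxygen substituents, so it remains open whether a phenyl ring bearing an amine or a carboxylic acid would move the number beyond the scatter. From the compounds shown here alone, it is equally open whether any of these steps would hold in other cell lines.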